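The source may hold more compounds than are shown below. What is called first, only, known or untested is meant among the compounds shown, and "the series" means these compounds.

Among the compounds with values here, in a functional assay on L1210 cells (Mus musculus) for inhibition (a lower number here means a stronger inhibitor, a higher number a weaker inhibitor), compound 1 `Cc1cn(C/C=C\CCl)c(=O)[nH]c1=O` gives 46000 nM and holds the higher of the two actual numbers so far. Compound 3 `Oc1nccc(NCC#CCCl)n1` gives 20000 nM in this assay and lies lower than compound 1 by a gap beyond the scatter. Compound 2 `Nc1nc(O)c2ncn(C=C=CCO)c2n1` has no number in this assay and is reported only as a limit (> 350000 nM).

Compound 4 `Cc1cn(CC#CCCl)c(=O)[nH]c1=O` is still unmeasured. It carries 3-chloroprop-1-yn-1-yl in place of 3-chloroprop-1-en-1-yl on a saturated chain carbon bound to an aromatic nitrogen. Within the data shown here, no measured pair isolates this change, so the expectation rests on thin ground. Compound 3 also has a triple bond in its chlorinated chain, although on a different core, and its value (20000 nM) tilts the expectation slightly toward a lower number. The estimated step (a 1.5-fold lower number from compound 1 to compound 4 (0.19 log units; within the scatter)) is expected to stay within the scatter. In this assay the expected value for compound 4 is 30000 nM with an estimated range of 10000 nM to 90000 nM for this measurement.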

Compound 4, half-maximal inhibitory concentration: 140000 nM
For compound 4 the middle estimate is 4.7-fold (0.67 log units) below the measured one; measured number outside the range, above it.
By their numbers in this assay, from the lowest: compound 3; then compound 1; then compound 4. At a limit, above all of these: compound 2.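

The series now holds its first comparison that differs in one place: in this assay, 3-chloroprop-1-yn-1-yl in place of 3-chloroprop-1-en-1-yl on a saturated chain carbon bound to an aromatic nitrogen gives a 3.0-fold higher number from compound 1 to compound 4 (0.48 log units; beyond the scatter), which makes the triple-bond chain the weaker inhibitor of the two on the shared core. The position therefore responds to the type of bond in the chain even though the count of heavy atoms stays the same, and compound 3, which also has a triple bond in a chlorinated chain but sits on a different core, cannot be read against this step. Nothing on hand gives a measured account of why the number moves this way.

From the compounds shown here alone, whether the same swap moves the number in the same direction on a different core remains open. Also open, going by these compounds, is how a bromine or an amine at the end of the chain in place of chlorine, or a longer chain, would read at this position on the core of compound 1.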